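The source may hold more compounds than are shown below. What is called first, only, known or untested is meant among the compounds shown, and "the series" means these compounds.

Measured in a functional assay on the whole organism with Rattus norvegicus as the target; on this read-out higher numbers stand for an effect only at larger amounts of compound and lower numbers for an effect already at smaller amounts:
- compound 1 `CCCCCc1ccc2nc(N)sc2c1`: 7.5 mg/kg
- compound 2 `CC(C)(C)Cc1ccc2nc(N)sc2c1`: > 10 mg/kg (a limit of the assay, not a number)

Compound 2 stands at the limit of > 10 mg/kg in this assay, at which 1 of the 2 values shown sits, so it has a limit and no exact number. Compound 3 `Nc1nc2ccc(SC(F)(F)F)cc2s1` differs from it at a single place, with (trifluoromethyl)sulfanyl in place of neopentyl on an aromatic carbon. For the measured compounds named here, only one measured step bears on this change: an at least 1.3-fold higher number from compound 1 to compound 2 (0.12 log units; that floor lies within the scatter). That step alters only a carbon chain, so it is a loose guide to a group carrying sulfur and fluorine. Compound 1 gives a measured 7.5 mg/kg with a chain in that place, so a measured number of similar size is expected for compound 3, with wide uncertainty. The expected change is an at least 2.5-fold lower number from compound 2 to compound 3 (0.39 log units; beyond the scatter). For compound 3 the estimate is 4 mg/kg, with the result expected between 1.3 mg/kg and 11 mg/kg.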

Compound 3, dose for half-maximal effect: 8 mg/kg
Compound 3: the middle estimate sits 2.0-fold (0.30 log units) below what was measured; the range from low to high includes it.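

In this assay, for the compounds shown here, the one step with exact numbers at both ends is a 1.1-fold higher number from compound 1 to compound 3 (0.03 log units; within the scatter), so exchanging the pentyl chain for (trifluoromethyl)sulfanyl, a group that is not a carbon chain, leaves the dose needed without a readable change. Against neopentyl, the change reads as an at least 1.2-fold lower number from compound 2 to compound 3 (0.09 log units; that floor lies within the scatter), which gives only a floor and not a full size. Compound 2 itself stands at a limit, not a number: the limit of > 10 mg/kg in this assay, at which 1 of the 3 values shown sits.

As far as these compounds go, whether an amine, a carboxylic acid or a much longer chain in this place would move the dose beyond the scatter stays open. No step among the compounds shown is printed as beyond the scatter, so what would raise or lower the dose at this position remains unknown.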